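Same aryl swap on a second core, read by radioligand binding

This account rests on a few compounds, and the source may have more. Where it says the series, first, only, none or still open, it means among the compounds named here.

Compound 1 `O=C1C2CCCN2C(=O)N1CN1CCN(c2cccc(Cl)c2)CC1` gives 292 nM in an assay on isolated protein for binding affinity to Adrenergic receptor alpha-1 (Rattus norvegicus), read by radioligand binding; on this read-out lower numbers stand for stronger inhibition and higher numbers for weaker inhibition.
Compound 2 `O=C1C2CCCN2C(=O)N1CN1CCN(c2ccc(F)cc2)CC1` gives > 1000 nM in this assay, which is a limit of the assay rather than a number.
Compound 3 `O=C1C2CCCCN2C(=O)N1CN1CCN(c2cccc(Cl)c2)CC1` gives 135 nM in this assay.

Compound 1 and compound 3 share the same arrangement apart from their cores; how the two cores differ is not broken down here. Between them, compound 3 sits at the lower number, and its gap to compound 1 lies beyond the usual scatter.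

The change from compound 1 to compound 2 is 4-fluorophenyl in place of 3-chlorophenyl on an amine nitrogen in a ring. It brought an at least 3.4-fold higher number from compound 1 to compound 2 (0.53 log units; beyond the scatter), and the true size of that step is hidden because compound 2 sits at the limit of > 1000 nM in this assay, at which 1 of the 3 values shown sits.

Compound 4 `O=C1C2CCCCN2C(=O)N1CN1CCN(c2ccc(F)cc2)CC1` is not yet measured. It stands to compound 3 as compound 2 stands to compound 1: the change is 4-fluorophenyl in place of 3-chlorophenyl on an amine nitrogen in a ring, the same change at the same kind of place, only on the other core. The expectation for compound 4 in this assay rests on the step seen from compound 1 to compound 2, which is an at least 3.4-fold higher number from compound 1 to compound 2 (0.53 log units; beyond the scatter), starting now from the lower number of compound 3, 135 nM. For compound 4 the estimated step is a 4.4-fold higher number from compound 3 to compound 4 (0.65 log units; beyond the scatter), at least as large as the earlier one. Compound 4 is therefore expected to give about 600 nM in this assay, between 250 nM and 2000 nM, with a real chance that only a limit is reported.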

Compound 4, inhibition constant: 869 nM
For compound 4 the middle estimate is 1.4-fold (0.16 log units) below the measured one, within the range that was stated.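

In this assay, the change from 3-chlorophenyl to 4-fluorophenyl on the amine nitrogen in a ring carried over to the second core in its direction, since on the core of compound 3 it brought a 6.4-fold higher number from compound 3 to compound 4 (0.81 log units; beyond the scatter). Whether the size of the step also carries over is not shown, as the comparison with the step on the core of compound 1 stays unresolved: the same change on two cores in this assay, an at least 3.4-fold higher number (0.53 log units; beyond the scatter) from compound 1 to compound 2 and a 6.4-fold higher number (0.81 log units; beyond the scatter) from compound 3 to compound 4; the limit leaves it open whether they differ Compound 2 gives > 1000 nM, which is a limit of the assay and not a number, so only the pair on the second core has a true number at both ends, and the agreement in direction rests on just two cores.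

The two aryl groups shown differ both in their halogen and in where it sits on the phenyl ring, so the compounds leave open which of these two differences goes with the higher number. From the compounds shown here alone, how 3-fluorophenyl, 4-chlorophenyl or a plain phenyl group would read on either core also remains open, and these groups would separate the halogen from its place on the ring.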